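Fluoro Replaced by Hydrogen on Compound 2

The compounds below may be only part of what the source reports. "The series", "measured", "known", "first", "only" and "open" are said of these compounds alone.

In an in vivo ADME assay on the whole organism (strain Sprague-Dawley) for pharmacokinetics, with Rattus norvegicus as the target (a lower number here means slower removal, a higher number faster removal of the compound), compound 2 (`C[C@@H]1C(=O)N[C@H](Cc2ccc(F)cc2)C(=O)NCCCc2ccc(F)cc2OCCN[C@@H](C2CC2)C(=O)N1C`) gives 28 mL/min/kg, a value within the scatter of compound 1 (`CC(C)[C@@H]1NC[C@@H](C)Oc2ccccc2CCCNC(=O)[C@@H](Cc2ccc(F)cc2)NC(=O)[C@@H](C)N(C)C1=O`) at 40 mL/min/kg. Compound 3 (`C[C@@H]1C(=O)N[C@H](Cc2ccc(F)cc2)C(=O)NCCCc2cccc3c2O[C@H](CC3)CN[C@@H](C2CC2)C(=O)N1C`) gives 13 mL/min/kg, lower than compound 2 by more than the scatter. Compound 4 (`C[C@@H]1C(=O)N[C@H](Cc2ccc(F)cc2)C(=O)NCCCc2ccccc2OCCN[C@@H](C2CC2)C(=O)N1C`) has not yet been measured. It carries hydrogen in place of fluoro on an aromatic carbon of compound 2 (hydrogen in place of fluoro on an aromatic carbon). For the measured compounds named here, no measured pair shows this change on its own, so the expectation has no direct precedent. A small rise in this assay, not beyond the scatter, is expected, with an estimated 1.2-fold higher number from compound 2 to compound 4 (0.07 log units; within the scatter). The estimate for compound 4 is 33 mL/min/kg, with an expected range of 17 mL/min/kg to 60 mL/min/kg.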

Compound 4, clearance: 72 mL/min/kg
Beside the measured number, compound 4's estimate is 2.2-fold (0.34 log units) below it; the whole stated range lies below it.
By their numbers in this assay, from the lowest: compound 3; then compounds 2, 1 and 4 (each within the scatter of the next, the first and the last beyond it).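

In this assay, for the compounds shown here, hydrogen in place of fluoro on this aromatic carbon gives a 2.6-fold higher number from compound 2 to compound 4 (0.41 log units; beyond the scatter), so this change, read here on its own for the first time, moves the number by more than the scatter. Fluoro at this position therefore goes with slower removal in compound 2, which the earlier compounds could not show. Nothing shown explains this step. Going by these compounds, whether chloro, methyl or methoxy on this carbon would match fluoro remains open. So does whether the step would hold on a different core.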